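Halogen swap on an otherwise inactive pair of scaffolds

This account rests on a few compounds, and the source may have more. Where it says the series, first, only, none or still open, it means among the compounds named here.

Compound 1 `COc1ccc([C@@H]2c3c(OC)cc(OC)cc3C(SCc3ccc(F)cc3)[C@H]2c2cc(OC)cc(OC)c2)cc1` gives in a functional assay on RAW264.7 cells (Mus musculus) for inhibition, with stated times of 2 h and 24 h (on this read-out lower numbers stand for stronger inhibition and higher numbers for weaker inhibition), only a limit, > 200000 nM. Compound 2 `COc1ccc([C@@H]2c3c(OC)cc(OC)cc3C(SCc3ccc(Cl)cc3)[C@H]2c2cc(OC)cc(OC)c2)cc1` gives in this assay only a limit, > 200000 nM. Compound 3 `COc1ccc([C@@H]2c3c(OC)cc(OC)cc3C(C(O)c3ccc(F)cc3)[C@H]2c2cc(OC)cc(OC)c2)cc1` gives in this assay only a limit, > 200000 nM.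

From compound 1 to compound 2 the change is chloro in place of fluoro on an aromatic carbon, and the step that the two limits leave unreadable from compound 1 to compound 2 cannot be read, since both values sit at the limit of > 200000 nM in this assay, at which 3 of the 3 values shown sit. The two cores differ by (4-fluorophenyl)(hydroxy)methyl in place of (4-fluorobenzyl)sulfanyl on a saturated ring carbon, and a step that the two limits leave unreadable from compound 1 to compound 3 as well as a step that the two limits leave unreadable from compound 2 to compound 3 are equally unreadable. Compound 4 `COc1ccc([C@@H]2c3c(OC)cc(OC)cc3C(C(O)c3ccc(Cl)cc3)[C@H]2c2cc(OC)cc(OC)c2)cc1` carries the same change, (chloro in place of fluoro on an aromatic carbon), on the core of compound 3. The step that the limit leaves unreadable from compound 3 to compound 4 in this assay is expected to be small, as compound 1 and compound 2 gave no readable difference (a step that the two limits leave unreadable from compound 1 to compound 2). Compound 4 is therefore estimated at 300000 nM in this assay, between 100000 nM and 1000000 nM, most likely again reported only as a limit.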

Compound 4, half-maximal inhibitory concentration: > 200000 nM
Compound 4: a limit, no number; the forecaster's own chance of this, stated with the estimate: 90%; the middle value is on the limit's open side.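

Compound 4 also gives only a limit in this assay, so no step between it and compound 1, compound 2 or compound 3 can be read: the limit of > 200000 nM in this assay, at which 4 of the 4 values shown sit.

Which change to the shared core would give a measurable inhibition stays open.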